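This account rests on a few compounds, and the source may have more. Where it says the series, first, only, none or still open, it means among the compounds named here.

Compound 1 `COc1ccc(N/C(CCNC2=CC(=O)c3ccccc3C2=O)=N\S(=O)(=O)c2ccc(C)cc2)cc1` gives 7590 nM in a functional assay on HeLa cells (Homo sapiens) for cytotoxicity, read by MTT assay, with a stated time of 48 h; a lower number here means a stronger inhibitor, a higher number a weaker inhibitor. Compound 2 `Cc1ccc(S(=O)(=O)/N=C(/CCNC2=CC(=O)c3ccccc3C2=O)Nc2cccc(C(F)(F)F)c2)cc1` gives 77600 nM in this assay.

Among the two measured numbers in this assay, compound 2 stands highest; its nearest neighbour is compound 1, which differs only in the group on the amine nitrogen, and the step of a 10-fold higher number from compound 1 to compound 2 (1.01 log units; beyond the scatter) is large and beyond the scatter. Compound 3 `Cc1ccc(S(=O)(=O)/N=C(/CCNC2=CC(=O)c3ccccc3C2=O)Nc2ccc(F)c(F)c2)cc1` carries the change (3,4-difluorophenyl in place of 3-(trifluoromethyl)phenyl on an amine nitrogen). Among the compounds with values here, no measured step covers this exact exchange; the only step at this position, a 10-fold higher number from compound 1 to compound 2 (1.01 log units; beyond the scatter), shows that the aryl group on the amine nitrogen can move the number strongly, but the data do not fix the direction for a difluorophenyl. Compound 3 is therefore expected to land between the two measured values, with an estimated step of a 2.6-fold lower number from compound 2 to compound 3 (0.41 log units; beyond the scatter) and wide uncertainty. The estimate for compound 3 in this assay is 30000 nM, within a range from 7000 nM to 120000 nM.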

Compound 3, half-maximal inhibitory concentration: 8790 nM
Beside the measured number, compound 3's estimate is 3.4-fold (0.53 log units) above it; the measured number falls inside the stated range.
By their numbers in this assay, from the lowest: compounds 1 and 3 (each within the scatter of the next); then compound 2.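

In this assay, placing 3,4-difluorophenyl on the amine nitrogen in place of 3-(trifluoromethyl)phenyl gives a clear step (an 8.8-fold lower number from compound 2 to compound 3 (0.95 log units; beyond the scatter)), so the high number of compound 2 does not extend to every fluorine-bearing aryl group at this position. The exchange of 4-methoxyphenyl for 3,4-difluorophenyl gives a step (a 1.2-fold higher number from compound 1 to compound 3 (0.06 log units; within the scatter)) that leaves compound 1 and compound 3 indistinguishable, although their aryl groups carry different substituents, and among these three compounds only compound 2 stands apart. No evidence is available that bears on why these aryl groups compare as they do.

The compounds shown leave open where a plain phenyl ring would fall, whether with compound 1 and compound 3 or with compound 2. They also leave open how a non-aromatic group on this nitrogen, such as cyclohexyl, would compare.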